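The compounds below may be only part of what the source reports. "The series", "measured", "known", "first", "only" and "open" are said of these compounds alone.

Three compounds that share one core and differ only in the length of a saturated chain have been tested in a functional assay on HeLa cells (Homo sapiens) for cytotoxicity, read by cell counting, with a stated time of 48 h; a lower number here means that less compound is needed, a higher number that more compound is needed for the effect. Compound 1 `CCCCCCCCCC(=O)O[C@H]1[C@H](O)[C@H](n2ccc(N)nc2=O)O[C@@H]1CO` gives 0.09 ug/mL. Compound 2 `CCCCCC(=O)O[C@H]1[C@H](O)[C@H](n2ccc(N)nc2=O)O[C@@H]1CO` gives 0.05 ug/mL. Compound 3 `CCCCCCCCCCCCCC(=O)O[C@H]1[C@H](O)[C@H](n2ccc(N)nc2=O)O[C@@H]1CO` gives 0.08 ug/mL. On these numbers compound 3 stands second highest of the three; its nearest neighbour is compound 1 and its furthest is compound 2, and both gaps lie within the scatter.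

Compound 4 `CCCCCCCCCCCCCCCCCCCC(=O)O[C@H]1[C@H](O)[C@H](n2ccc(N)nc2=O)O[C@@H]1CO` differs from compound 3 by hexyl in place of hydrogen on a saturated chain carbon, ten or more bonds along the chain from a carbonyl carbon. Among the compounds with values here, the steps that bear on this are the earlier chain lengthenings: a 1.1-fold lower number from compound 1 to compound 3 (0.05 log units; within the scatter) and a 1.6-fold higher number from compound 2 to compound 3 (0.20 log units; within the scatter), with the shortening a 1.8-fold lower number from compound 1 to compound 2 (0.26 log units; within the scatter) pointing the same way. Lengthening the chain has so far produced no step beyond the scatter, so none is expected here either. Compound 4 is therefore estimated to give 0.1 ug/mL, with a range from 0.04 ug/mL to 0.3 ug/mL. This amounts to an expected step of a 1.3-fold higher number from compound 3 to compound 4 (0.10 log units; within the scatter), within the scatter.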

Compound 4, concentration for half-maximal effect: 0.1 ug/mL
Compound 4: middle estimate and measured number agree at the digits printed, within the range that was stated.
By their numbers in this assay, from the lowest: compounds 2, 3, 1 and 4 (each within the scatter of the next).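

Hexyl in place of hydrogen on a saturated chain carbon had not yet been tried, and in this assay it gives a 1.3-fold higher number from compound 3 to compound 4 (0.10 log units; within the scatter) as its step. Decyl in place of hydrogen, nine bonds along the chain from a carbonyl carbon, gives a 1.1-fold higher number from compound 1 to compound 4 (0.05 log units; within the scatter) as its step, so adding even this much saturated chain does not move the number beyond the scatter. Nothing available explains this flat reading in this assay.

All the chains shown are plain saturated ones, so it remains open whether a chain carrying an amine or a carboxylic acid would read differently. On these data alone, it also remains open whether a still longer chain would stay within the scatter of compound 4.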